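A few compounds are considered here, and "the series" means these few. Any claim that something is new, unique, unknown or untested is made for them only; others in the source may bear on it.

Measured compounds in an assay for inhibition of serine/threonine-protein kinase PLK2 (Homo sapiens), read by FRET and Z'-LYTE, with a stated time of 1 h; on this read-out higher numbers stand for weaker inhibition and lower numbers for stronger inhibition:

compound 1, `CC[C@@H]1C(=O)N(C)c2cnc(Nc3ccc(S(=O)(=O)NC)cc3)nc2N1C1CCCC1`: 3.4 nM
compound 2, `CCCNS(=O)(=O)c1ccc(Nc2ncc3c(n2)N(C2CCCC2)[C@H](CC)C(=O)N3C)cc1`: 17.8 nM
compound 3, `CC[C@@H]1C(=O)N(C)c2cnc(Nc3ccc(S(=O)(=O)NCCCO)cc3)nc2N1C1CCCC1`: 8.16 nM

Within this set compound 3 sits second highest of the three numbers; its nearest neighbour is compound 2, a 2.2-fold lower number from compound 2 to compound 3 (0.34 log units; beyond the scatter), and the furthest is compound 1, a 2.4-fold higher number from compound 1 to compound 3 (0.38 log units; beyond the scatter). The unmeasured compound 4, `CC[C@@H]1C(=O)N(C)c2cnc(Nc3ccc(S(=O)(=O)NCCO)cc3)nc2N1C1CCCC1`, differs from compound 3 as follows: hydroxy in place of hydroxymethyl on a saturated chain carbon, two bonds along the chain from a sulfonamide nitrogen.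

Among the measured compounds shown here, no measured step shortens a hydroxy-bearing chain on the sulfonamide nitrogen, so the bearing steps are indirect. Growing the chain from compound 1 gave a 2.4-fold higher number from compound 1 to compound 3 (0.38 log units; beyond the scatter) and a 5.2-fold higher number from compound 1 to compound 2 (0.72 log units; beyond the scatter), both raising the number, whereas adding hydroxy gave a 2.2-fold lower number from compound 2 to compound 3 (0.34 log units; beyond the scatter), lowering it. Compound 4 keeps the hydroxy of compound 3 but carries a shorter chain, closer to compound 1 in size, so a modest lowering of the number is expected, a 1.4-fold lower number from compound 3 to compound 4 (0.13 log units; within the scatter), though a result within the scatter would not surprise. The estimate for compound 3 therefore places compound 4 at 6 nM, within 2.5 nM to 15 nM.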

Compound 4, half-maximal inhibitory concentration: 7.86 nM
For compound 4 the middle estimate is 1.3-fold (0.12 log units) below the measured one; low and high end bracket the measured number.
By their numbers in this assay, from the lowest: compound 1; then compounds 4 and 3 (each within the scatter of the next); then compound 2.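

In this assay, among the compounds shown here, the change from 3-hydroxypropyl to 2-hydroxyethyl on the sulfonamide nitrogen gives a 1.0-fold lower number from compound 3 to compound 4 (0.02 log units; within the scatter), so this position tolerates that shortening with no readable change, something the earlier compounds could not show. The two hydroxy-bearing chains therefore sit together between compound 1 and compound 2, with a 2.3-fold lower number from compound 2 to compound 4 (0.35 log units; beyond the scatter) on one side and a 2.3-fold higher number from compound 1 to compound 4 (0.36 log units; beyond the scatter) on the other, and the shorter chain does not move the number towards that of compound 1. Nothing at hand explains why chain length stops mattering once the hydroxy is present.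

Going by these compounds, whether a longer chain such as 4-hydroxybutyl stays at the same level remains open. So does whether an amine or a carboxylic acid at the chain end can stand in for the hydroxy.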